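Pyridin-2-ylsulfonyl in Place of Methylsulfonyl: an Expected Limit

The compounds below may be only part of what the source reports. "The series", "measured", "known", "first", "only" and "open" are said of these compounds alone.

Measured in an assay on HEK293 cells for inhibition of prostaglandin E2 receptor EP4 subtype (Rattus norvegicus); on this read-out higher numbers stand for weaker inhibition and lower numbers for stronger inhibition:
- compound 1 `CC(C)(C)c1ccc(CN(Cc2cccc(CCC(=O)O)c2)S(=O)(=O)c2ccccc2)cc1`, a limit of the assay rather than a number: > 3200 nM
- compound 2 `CC(C)(C)c1ccc(CN(Cc2cccc(CCC(=O)O)c2)S(=O)(=O)c2ccc(Cl)cc2)cc1`, again only a limit of the assay: > 3200 nM
- compound 3 `CC(C)(C)c1ccc(CN(Cc2cccc(CCC(=O)O)c2)S(C)(=O)=O)cc1`, likewise only a limit of the assay: > 3200 nM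

Compound 3 therefore stands nowhere in particular on the numbers shown: all three values sit at the limit of > 3200 nM in this assay, at which 3 of the 3 values shown sit, so none of the compounds can be ranked against the others.

Compound 4 `CC(C)(C)c1ccc(CN(Cc2cccc(CCC(=O)O)c2)S(=O)(=O)c2ccccn2)cc1` differs from compound 3 by pyridin-2-yl in place of methyl on a sulfonyl sulfur. The measured steps that touch the same sulfonyl sulfur are a step that the two limits leave unreadable from compound 1 to compound 3 and a step that the two limits leave unreadable from compound 2 to compound 3; both connect two limits and have no readable size. Compound 1, which carries a phenyl on that sulfur, also gave only a limit, so an aromatic ring in this position is not seen to bring a readable gain. The step from compound 3 to compound 4 is expected to be a step that the limit leaves unreadable from compound 3 to compound 4, that is, no change readable beyond the scatter. For compound 4 the estimate is 5000 nM, within 1500 nM to 20000 nM, most likely reported as a limit.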

Compound 4, half-maximal inhibitory concentration: > 3200 nM
Compound 4 was reported as a limit (the forecaster's own chance of this, stated with the estimate: 75%); the middle value lies beyond the limit too.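

Compound 4 gives > 3200 nM, which is again a limit of the assay. No step linking compound 4 to compound 1, compound 2 or compound 3 can be read: the limit of > 3200 nM in this assay, at which 4 of the 4 values shown sit.

The compounds shown leave open whether any group on the sulfonyl sulfur gives a measurable inhibition.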